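The source may report more compounds than this note shows. Statements on the series, on what has been measured and on what is new or still open speak of the compounds shown alone.

The three measured compounds and their values in a functional assay on SW1573 cells (Homo sapiens) for inhibition, read by sulforhodamine B assay, with a stated time of 48 h (on this read-out lower numbers stand for stronger inhibition of growth and higher numbers for weaker inhibition of growth), are these:

Compound 1, `O=C(/C(=C/c1ccccc1)CCl)c1ccccc1`, gives 3600 nM.
Compound 2, `O=C(/C(=C/c1ccc(Cl)cc1)CCl)c1ccccc1`, gives 3900 nM.
Compound 3, `CC(=O)OC/C(=C/c1ccc(Cl)cc1)C(=O)c1ccc(Cl)cc1`, gives 5300 nM.

Compound 2 differs from compound 1 by chloro in place of hydrogen on an aromatic carbon, and this change made a step of a 1.1-fold higher number from compound 1 to compound 2 (0.03 log units; within the scatter). How the core of compound 3 differs from the core of compound 1 is not broken down here; their two values lie close together.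

Compound 4, `CC(=O)OC/C(=C/c1ccc(Cl)cc1Cl)C(=O)c1ccc(Cl)cc1`, is not yet measured. It differs from compound 3 by chloro in place of hydrogen on an aromatic carbon. For the measured compounds named here, this is the same kind of change as the one from compound 1 to compound 2, but the place is not the same: in compound 2 the chloro stands para to a large group, whereas in compound 4 it stands ortho to a large group and meta to a chloro group.

For compound 4 in this assay a step of a 1.0-fold higher number from compound 3 to compound 4 (0.02 log units; within the scatter) is expected, resting on the earlier step of a 1.1-fold higher number from compound 1 to compound 2 (0.03 log units; within the scatter), which stayed within the scatter. The estimate for compound 4 is therefore 5500 nM, expected to fall between 2500 nM and 12000 nM.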

Compound 4, concentration for 50% growth inhibition: 21000 nM
Compound 4: middle estimate off by 3.8-fold (0.58 log units), on the low side, outside the stated range (above it).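

In this assay, putting the chloro on the aromatic ring of compound 3 gave a 4.0-fold higher number from compound 3 to compound 4 (0.60 log units; beyond the scatter), so on this core the change weakened growth inhibition. Set beside the earlier case, the change did not carry over with the same size from one core to the other: the same change on two cores in this assay, a 1.1-fold higher number (0.03 log units; within the scatter) from compound 1 to compound 2 and a 4.0-fold higher number (0.60 log units; beyond the scatter) from compound 3 to compound 4, 3.7-fold (0.56 log units) apart, beyond the scatter of two such steps. This does not show that the core alone sets the size of the step, since the new chloro in compound 4 stands ortho to a large group and meta to a chloro group, a place not shared by the chloro of compound 2, and two pairs set no rule for the series.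

The compounds shown leave open whether a chloro in that same place on the core of compound 1 would give a step like the one on the core of compound 3. They also leave open how a fluoro, a methyl or a methoxy group in that place would read in this assay.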